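Swapping the aryl group on a shared core

The source may report more compounds than this note shows. Statements on the series, on what has been measured and on what is new or still open speak of the compounds shown alone.

In a functional assay on HT-29 cells (Homo sapiens) for cytotoxicity, read by MTT assay, with a stated time of 48 h, tested at 50 uM (a higher number here means a stronger effect of the compound at the concentration tested, a lower number a weaker effect), compound 1 `CS(=O)(=O)c1ccc(Cc2nnc3n2N=C(c2ccccc2)CS3)cc1` gives 46.7%, compound 2 `CS(=O)(=O)c1ccc(Cc2nnc3n2N=C(c2cc(Cl)sc2S(N)(=O)=O)CS3)cc1` gives 27.5%, and compound 3 `CS(=O)(=O)c1ccc(Cc2nnc3n2N=C(c2ccc(Cl)cc2Cl)CS3)cc1` gives 27.3%, the lowest of the three numbers, though compound 2 sits within the scatter of it. The steps of a number 19.2 percentage points lower from compound 1 to compound 2 (beyond the scatter) and a number 19.4 percentage points lower from compound 1 to compound 3 (beyond the scatter) show that two different substituted aryl groups in place of phenyl each lowered the read-out by a modest amount, while a number 0.2 percentage points lower from compound 2 to compound 3 (within the scatter) separates those two aryl groups not at all. Compound 4 `CS(=O)(=O)c1ccc(Cc2nnc3n2N=C(c2ccc(O)c(C(N)=O)c2)CS3)cc1` makes one more change of this kind: 3-carbamoyl-4-hydroxyphenyl in place of 2,4-dichlorophenyl on a carbon with a double bond to nitrogen. For the measured compounds named here, no measured step covers this group, so only the pattern that substituted aryls sit near one another is available. Compound 4 is therefore expected at 32%, between 15% and 50%. The expected step is a number 4.7 percentage points higher from compound 3 to compound 4 (within the scatter), within the scatter.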

Compound 4, a percentage reported as activity, at one concentration (the size of the read-out at that concentration, not a potency): 33.1%
The estimate for compound 4 lay 1.1 percentage points below the measured number; the range from low to high includes it.
By their numbers in this assay, from the lowest: compounds 3, 2 and 4 (each within the scatter of the next); then compound 1.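

In this assay, 3-carbamoyl-4-hydroxyphenyl, though built quite differently from the two earlier substituted groups, gives a number 5.8 percentage points higher from compound 3 to compound 4 (within the scatter) and a number 5.6 percentage points higher from compound 2 to compound 4 (within the scatter). Set against plain phenyl, it gives a number 13.6 percentage points lower from compound 1 to compound 4 (beyond the scatter), so all three substituted groups shown now part from phenyl in the same direction. Nothing available explains this shared difference. As far as these compounds go, whether the hydroxyl or the carbamoyl matters more on this ring stays open, since the two appear only together. Also open, from the compounds shown here alone, is what a carboxylic acid or an amine on the ring, or a longer alkyl chain in place of the ring, would give.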